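Dimethylamino for imidazol-1-yl on the propargylic chain carbon

A few compounds are considered here, and "the series" means these few. Any claim that something is new, unique, unknown or untested is made for them only; others in the source may bear on it.

Measured so far:
Compound 1 `CC1CCC(=O)N1CC#CCn1ccnc1`: > 100 mg/kg, a limit of the assay.
Compound 2 `CC1CCC(=O)N1CC#CCN(C)C`: 3.7 mg/kg.
Compound 3 `COC(=O)N(C)C(C)C#CCn1ccnc1`: 8 mg/kg.

In a functional assay on the whole organism for agonist activity, with Mus musculus as the target (a higher number here means that more compound is needed for the effect, a lower number that less compound is needed), compound 1 gives only a limit, > 100 mg/kg; the series has one value sitting there, (the limit of > 100 mg/kg in this assay, at which 1 of the 3 values shown sits). Compound 2 gives 3.7 mg/kg in this assay. The step of an at least 27-fold lower number from compound 1 to compound 2 (1.43 log units; beyond the scatter) goes with the change (dimethylamino in place of 1H-imidazol-1-yl on a saturated chain carbon bound to a triple-bonded carbon). Compound 3 gives 8 mg/kg in this assay; its core differs from that of compound 1, and that difference is not broken down here.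

Compound 4 `COC(=O)N(C)C(C)C#CCN(C)C` carries the same change on the core of compound 3, (dimethylamino in place of 1H-imidazol-1-yl on a saturated chain carbon bound to a triple-bonded carbon), at the same place as before. The step is expected to be a 5.3-fold lower number from compound 3 to compound 4 (0.73 log units; beyond the scatter), resting on an at least 27-fold lower number from compound 1 to compound 2 (1.43 log units; beyond the scatter), though that earlier step starts from a limit and so sets only a floor. Compound 4 is therefore expected to give about 1.5 mg/kg in this assay, within 0.3 mg/kg to 6 mg/kg.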

Compound 4, dose for half-maximal effect: 17.3 mg/kg
For compound 4 the middle estimate is 12-fold (1.06 log units) below the measured one; measured number above the stated range.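

In this assay, dimethylamino in place of 1H-imidazol-1-yl gives a 2.2-fold higher number from compound 3 to compound 4 (0.33 log units; beyond the scatter), so the change does not carry from one core to the other in size or in direction: the same change on two cores in this assay, an at least 27-fold lower number (1.43 log units; beyond the scatter) from compound 1 to compound 2 and a 2.2-fold higher number (0.33 log units; beyond the scatter) from compound 3 to compound 4, at least 58-fold (1.76 log units) apart, beyond the scatter of two such steps. Compound 1 gives only a limit of the assay, > 100 mg/kg. The two steps show that the result of this change depends on the core in these two pairs, but they do not show which part of the core decides it, and they give no rule for any further core.

Still open, on these data alone, is how another amine, such as diethylamino, would behave on either core. Also open, as far as these compounds go, is which of the differences between the core of compound 1 and the core of compound 3 goes with the gap between the two steps.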